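This account rests on a few compounds, and the source may have more. Where it says the series, first, only, none or still open, it means among the compounds named here.

Measured compounds:
- compound 1, `COC(=O)c1c(OC)cc(C2OC(c3ccc(N)c(C)c3)=NN2C(C)=O)cc1OC`: 0.28 uM
- compound 2, `COc1cc(C2OC(c3ccc(N(C)C)cc3)=NN2C=O)cc(OC)c1OC`: 0.096 uM

In a functional assay on HCT-15 cells (Homo sapiens) (on this read-out lower numbers stand for an effect already at smaller amounts and higher numbers for an effect only at larger amounts of compound), compound 1 gives 0.28 uM and compound 2 gives 0.096 uM. Compound 2 holds the lower of the two numbers, and its gap to compound 1 lies beyond the scatter. The two compounds differ in several places at once, so nothing is known about the weight of any single change.

Compound 3, `COc1cc(C2OC(c3ccc(N(C)C)cc3)=NN2C(=O)COC(C)=O)cc(OC)c1OC`, is not yet measured. It differs from compound 2 in one place: acetoxymethyl in place of hydrogen on a carbonyl carbon. The acetoxymethyl group enters on the carbonyl carbon whose other neighbour is the amide-type nitrogen in a ring. Going by the values given here, no measured pair in this set isolates this change.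

The estimate for compound 3 rests on compound 2 alone: a step of a 2.1-fold higher number from compound 2 to compound 3 (0.32 log units; beyond the scatter) is expected, a modest move toward a higher number. Compound 3 is expected to give 0.2 uM in this assay, within 0.05 uM to 0.8 uM.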

Compound 3, concentration for half-maximal effect: 0.019 uM
Beside the measured number, compound 3's estimate is 11-fold (1.02 log units) above it; the whole stated range lies above it.
By their numbers in this assay, from the lowest: compound 3; then compound 2; then compound 1.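

Going by these compounds alone, the first single-place step falls on the carbonyl carbon whose other neighbour is the amide-type nitrogen in a ring. In this assay, acetoxymethyl in place of hydrogen there gives a 5.1-fold lower number from compound 2 to compound 3 (0.70 log units; beyond the scatter), so this position affects the read-out, and a chain of this size on it goes with a lower number rather than a higher one. No measurement bears on the reason for this step.

Still open, as far as these compounds go, is whether the whole acetoxymethyl group is needed, or whether a smaller group such as hydroxymethyl or methoxymethyl on the same carbonyl carbon would give a similar number in this assay. Also open, from the compounds shown here alone, is whether a longer chain, an amine or a carboxylic acid there would extend the step or reverse it.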